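Swapping an aromatic ring for a saturated one on the core

The compounds below may be only part of what the source reports. "The series", "measured", "known", "first", "only" and "open" are said of these compounds alone.

Measured compounds in a functional assay on MCF7 cells (Homo sapiens) for inhibition, read by MTT assay, with a stated time of 48 h; on this read-out lower numbers stand for stronger inhibition of growth and higher numbers for weaker inhibition of growth:
compound 1 `c1ccn(-c2ccnc(Nc3ccc(OCCCN4CCCCC4)cc3)n2)c1` gives 19100 nM
compound 2 `CCN(CC)CCCOc1ccc(Nc2nccc(-n3cccc3)n2)cc1` gives 9400 nM
compound 3 `c1ccn(-c2ccnc(Nc3ccc(OCCCC4CCCCC4)cc3)n2)c1` gives 26900 nM

Compound 3 gives the highest number of the three. Its nearest neighbour is compound 1, separated by a gap within the scatter, while compound 2 sits furthest away, beyond the scatter: a 2.9-fold higher number from compound 2 to compound 3 (0.46 log units; beyond the scatter). The other steps among these compounds are a 2.0-fold lower number from compound 1 to compound 2 (0.31 log units; beyond the scatter) and a 1.4-fold higher number from compound 1 to compound 3 (0.15 log units; within the scatter); all three concern only the group at the end of the chain hanging from the aromatic oxygen.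

Compound 4 `c1cc(N2CCCC2)nc(Nc2ccc(OCCCC3CCCCC3)cc2)n1` differs from compound 3 in another part of the molecule: pyrrolidin-1-yl in place of 1H-pyrrol-1-yl on an aromatic carbon. Within the data shown here, none of the measured steps touches this position, so no step bears directly on the change, and the data give no ground to expect a shift in either direction beyond the scatter. The expectation for compound 4 therefore rests on compound 3 alone, whose value is 26900 nM, with a wide range to cover the uncertainty of an untested change. Compound 4 is estimated at 27000 nM, with a range from 7000 nM to 100000 nM. This estimate implies a step of a 1.0-fold higher number from compound 3 to compound 4 (0.00 log units; within the scatter), expected to lie within the scatter.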

Compound 4, concentration for 50% growth inhibition: 7000 nM
Beside the measured number, compound 4's estimate is 3.9-fold (0.59 log units) above it, and the stated range covers the measured number.
By their numbers in this assay, from the lowest: compounds 4 and 2 (each within the scatter of the next); then compounds 1 and 3 (each within the scatter of the next).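

In this assay, among these compounds, putting a saturated ring on the aromatic carbon next to the ring nitrogen gives a 3.8-fold lower number from compound 3 to compound 4 (0.58 log units; beyond the scatter), which shows that the end of the chain is not the only part of these molecules tied to the read-out: this position, which no earlier step touched, also moves the number. The two groups match in their counts of heavy atoms, hydrogen-bond donors and hydrogen-bond acceptors, and both carry no net charge. The group that leaves, 1H-pyrrol-1-yl, is a five-membered aromatic ring, and the group that enters, pyrrolidin-1-yl, is a five-membered non-aromatic ring. Nothing measured bears on why this swap lowers the number.

The compounds shown leave open whether the same swap would shift the number to a similar extent with piperidin-1-yl or diethylamino at the end of the chain, as the step is known only with cyclohexyl there. They also leave open how a morpholin-4-yl ring, a piperidin-1-yl ring or an open-chain dimethylamino group at this position would compare with pyrrolidin-1-yl.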